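Chain extension of the acid in compound 1

The compounds below may be only part of what the source reports. "The series", "measured", "known", "first", "only" and "open" are said of these compounds alone.

Compound 1 `Cc1cc(C(=O)O)ccc1-c1noc(-c2ccc(C3CCCCC3)cc2)n1` carries the acid directly on the ring of the shared core. In a functional assay on CHO cells with sphingosine 1-phosphate receptor 2 (Homo sapiens) as the target, read by GTPgammaS binding (on this read-out higher numbers stand for an effect only at larger amounts of compound and lower numbers for an effect already at smaller amounts), compound 1 gives > 10000 nM, which is a limit of the assay and not a number. Compound 2 `Cc1cc(CCC(=O)O)ccc1-c1noc(-c2ccc(OC(C)C)c(C(F)(F)F)c2)n1` gives > 10000 nM, also a limit. Compound 3 `Cc1cc(CCC(=O)O)ccc1-c1noc(-c2ccc(OC(C)C)c(Cl)c2)n1` gives > 10000 nM, again a limit. Among the measured compounds shown here, the one measured step, a step that the two limits leave unreadable from compound 2 to compound 3, concerns the substituent on the outer aryl ring and not the acid, and both of its ends sit at the limit (the limit of > 10000 nM in this assay, at which 3 of the 3 values shown sit), so its size cannot be read. Compound 4 `Cc1cc(CCCCCC(=O)O)ccc1-c1noc(-c2ccc(C3CCCCC3)cc2)n1` differs from compound 1 by 5-carboxypentyl in place of carboxy on an aromatic carbon. For the measured compounds named here, no measured pair changes the acid chain, so nothing measured bears directly on this step. With compound 1 standing at the limit, the expectation for compound 4 is another limit rather than a number. The estimate for compound 4 is 12000 nM, with a range from 3000 nM to 50000 nM. The step that the limit leaves unreadable from compound 1 to compound 4 is expected to remain unreadable against the limit.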

Compound 4, half-maximal effective concentration: > 10000 nM
Compound 4 ended at the assay's limit (the forecaster's own chance of this, stated with the estimate: 70%); the middle value is on the limit's open side.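

Compound 1 and compound 4 both sit at a limit in this assay, so no new step can be read between them: the limit of > 10000 nM in this assay, at which 4 of the 4 values shown sit.

The compounds shown leave open whether any acid chain or outer aryl substituent on the shared core gives a measurable value in this assay.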